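Replacing a branched side chain with a sulfur-containing ring

The source may hold more compounds than are shown below. What is called first, only, known or untested is meant among the compounds shown, and "the series" means these compounds.

Compound 1 `Nc1ncnc2c1ncn2[C@@H]1CO[C@H](COS(=O)(=O)NC(=O)[C@@H]2CCCN2)[C@@H](O)C1`: 2800 nM
Compound 2 `CSCC[C@H](N)C(=O)NS(=O)(=O)OC[C@H]1OC[C@@H](n2cnc3c(N)ncnc32)[C@H](O)[C@@H]1O`: 5200 nM
Compound 3 `CC(C)C[C@H](N)C(=O)NS(=O)(=O)OC[C@H]1O[C@@H](n2cnc3c(N)ncnc32)[C@H](O)[C@@H]1O`: 1100 nM

Of the compounds shown here, three have been tested in a functional assay on PBMC cells (Homo sapiens) for inhibition; on this read-out lower numbers stand for stronger inhibition and higher numbers for weaker inhibition. Compound 3 gives the lowest number of the three; its nearest neighbour is compound 1, and compound 2 stands furthest away. Both gaps lie beyond the usual scatter, so compound 3 is the strongest inhibitor among the measured compounds.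

Compound 4 `Nc1ncnc2c1ncn2[C@@H]1O[C@H](COS(=O)(=O)NC(=O)[C@@H]2CSCN2)[C@@H](O)[C@H]1O` has not yet been measured. It differs from compound 3 in one place: 1,3-thiazolidin-4-yl in place of 1-amino-3-methylbutyl on a carbonyl carbon. For the measured compounds named here, since no pair of measured compounds differs in exactly this way, the size of the step is uncertain. Compound 1 carries a ring at the same position, though on a different sugar, and gives a higher number than compound 3, which suggests that a ring at this place is not favoured. A weakening step of moderate size is expected from compound 3 to compound 4 , a 3.2-fold higher number from compound 3 to compound 4 (0.50 log units; beyond the scatter), with a wide range. Compound 4 is therefore expected to give about 3500 nM in this assay , between 900 nM and 14000 nM.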

Compound 4, half-maximal inhibitory concentration: 550 nM
Estimate against measurement, compound 4: 6.4-fold (0.80 log units) above; measured number outside the range, below it.
By their numbers in this assay, from the lowest: compounds 4 and 3 (each within the scatter of the next); then compounds 1 and 2 (each within the scatter of the next).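

In this assay, putting 1,3-thiazolidin-4-yl in place of 1-amino-3-methylbutyl on a carbonyl carbon gives a 2.0-fold lower number from compound 3 to compound 4 (0.30 log units; within the scatter). For the compounds shown here, no earlier pair of compounds differed at this place alone, and this one shows that an open branched chain can give way to a five-membered non-aromatic ring containing sulfur with no change beyond the usual scatter on this read-out. Nothing available explains this result.

On these data alone, whether the sulfur matters stays open, and the oxygen analogue, 1,3-oxazolidin-4-yl, on the same core would test that directly. Equally open, as far as these compounds go, is how much the ring nitrogen contributes, which a cyclopentyl group on the same carbonyl carbon would help to show.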